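Removing a nitro group from a sodium channel binder

The source may report more compounds than this note shows. Statements on the series, on what has been measured and on what is new or still open speak of the compounds shown alone.

Measured so far:
compound 1, `NC(=O)n1ccc(-c2ccc(Oc3ccc([N+](=O)[O-])cc3)cc2)n1`: 31 nM
compound 2, `Fc1ccc(Oc2ccc(-c3cc[nH]n3)cc2)cc1`: 200 nM

Compound 1 and compound 2 were both examined in an assay on HEK293 cells for binding affinity to sodium channel protein type 4 subunit alpha (Homo sapiens); on this read-out lower numbers stand for stronger inhibition and higher numbers for weaker inhibition. Compound 1 gives the lower of the two numbers, and compound 2 sits at a higher number, a gap beyond the scatter. The two structures differ in more than one place, so the pair cannot be read as a single step.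

Compound 3 is `NC(=O)n1ccc(-c2ccc(Oc3ccccc3)cc2)n1`. It has not yet been measured. Compared with compound 1, the change is hydrogen in place of nitro on an aromatic carbon. Among the compounds with values here, no measured pair shows this change on its own, so its effect here is unknown. Loss of a group of this kind may cost some binding, but the size is uncertain.

For compound 3 the expected value in this assay is 80 nM, with a range from 25 nM to 250 nM, which is an estimated step of a 2.6-fold higher number from compound 1 to compound 3 (0.41 log units; beyond the scatter).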

Compound 3, inhibition constant: 35 nM
Estimate against measurement, compound 3: 2.3-fold (0.36 log units) above; low and high end bracket the measured number.
By their numbers in this assay, from the lowest: compounds 1 and 3 (each within the scatter of the next); then compound 2.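

With hydrogen in place of nitro on the aromatic carbon para to a large group, this assay gives a 1.1-fold higher number from compound 1 to compound 3 (0.05 log units; within the scatter). The nitro group, with its 3 heavy atoms, is therefore not required for the binding value seen with compound 1, and compound 1 and compound 3 cannot be told apart at this position. Nothing at hand explains why this exchange leaves the two numbers within the scatter of each other. The compounds shown leave open whether other groups at this place, such as an amine or a carboxylic acid, would match hydrogen and nitro or would separate from them. They also leave open whether hydrogen and nitro would stay as close on any core other than that of compound 1.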